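Amide nitrogen variation: from compound 2 to compound 4

A few compounds are considered here, and "the series" means these few. Any claim that something is new, unique, unknown or untested is made for them only; others in the source may bear on it.

Measured so far in a functional assay on HeLa cells (Homo sapiens) for inhibition, read by MTT assay, with a stated time of 48 h; a lower number here means a stronger inhibitor, a higher number a weaker inhibitor:
compound 1 `COc1ccc(CNC(=O)/C=C/c2coc3cc(O)ccc3c2=O)cc1`: > 100000 nM (a limit, not a number).
compound 2 `COc1cccc(NC(=O)/C=C/c2coc3cc(OC)ccc3c2=O)c1`: 19200 nM.
compound 3 `Cc1ccccc1NC(=O)/C=C/c1coc2cc(O)ccc2c1=O`: 8670 nM.

Compound 1 is reported only as a limit, (the limit of > 100000 nM in this assay, at which 1 of the 3 values shown sits). Of the two real numbers, compound 2 gives the higher one; compound 3 lies lower, by a gap beyond the usual scatter. Among the measured compounds shown here, no step between measured compounds that differ in one place exists in this set.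

Compound 4 `COc1ccc2c(=O)c(/C=C/C(=O)NCc3ccc(F)cc3F)coc2c1` differs from compound 2 as follows: 2,4-difluorobenzyl in place of 3-methoxyphenyl on an amide-type nitrogen. Compound 1 shows that a change at the amide-type nitrogen can push the result to the limit > 100000 nM. The step from compound 2 to compound 4 is expected to weaken, a 2.1-fold higher number from compound 2 to compound 4 (0.32 log units; beyond the scatter), with a fair chance of only a limit. Compound 4 is estimated at 40000 nM, range 10000 nM to 150000 nM.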

Compound 4, half-maximal inhibitory concentration: > 100000 nM
Compound 4: only a limit was reported; the forecaster's own chance of this, stated with the estimate: 40%; middle value at least 2.5-fold (0.39 log units) from the limit.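

In this assay, among the compounds shown here, the single change at the amide-type nitrogen gives an at least 5.2-fold higher number from compound 2 to compound 4 (0.71 log units; beyond the scatter), so this position alone can take a measurable compound to the limit. Compound 4 gives > 100000 nM, which is a limit and not a number. Two of the compounds shown now sit there: the limit of > 100000 nM in this assay, at which 2 of the 4 values shown sit.

Going by these compounds, the true size of the step stays open, as does whether the fluorine atoms or the benzyl form of the group accounts for it. An unsubstituted benzyl or a 3-methoxybenzyl group on this nitrogen would bear on that question.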